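From chloro to 4-fluorophenyl: a step toward stronger antagonism

The source may report more compounds than this note shows. Statements on the series, on what has been measured and on what is new or still open speak of the compounds shown alone.

Compound 1, `N#Cc1ccc(-c2ccc(C(=O)Nc3ccc4cccnc4c3)cn2)cc1`, gives < 6.6 in an in vitro functional assay on 1321-N1 cells for antagonist activity at transient receptor potential cation channel subfamily V member 1 (Homo sapiens), read by FLIPR and calcium flux (a lower number here means a less potent compound, a higher number a more potent compound, by a factor of ten per unit of this negative logarithm), which is a limit of the assay.
Compound 2, `O=C(Nc1ccc2cccnc2c1)c1ccc(-c2ccccc2F)nc1`, gives 8.7 in this assay.
Compound 3, `O=C(Nc1ccc2cccnc2c1)c1ccc(Cl)nc1`, gives < 6.7 in this assay, again only a limit.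

Compound 3 therefore stands at a limit, with no exact number. Compound 4, `O=C(Nc1ccc2cccnc2c1)c1ccc(-c2ccc(F)cc2)nc1`, is not yet measured; it differs from compound 3 by 4-fluorophenyl in place of chloro on an aromatic carbon. The closest measured step is a number at least 2.00 log units lower from compound 2 to compound 3 (beyond the scatter), where taking away a 2-fluorophenyl lost a large amount. Against that, compound 1 with a 4-cyanophenyl sits at a limit, and the step that the two limits leave unreadable from compound 1 to compound 3 cannot be read. Compound 4 is expected to gain, with an estimated step of a number at least 1.00 log units higher from compound 3 to compound 4 (beyond the scatter). The estimate for compound 4 is 7.7, between 6.4 and 9.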

Compound 4, negative logarithm of the antagonist equilibrium constant: 8.2
Compound 4: the middle estimate sits 0.50 log units below what was measured; the range from low to high includes it.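

Two different fluorophenyl groups now stand clear of chloro at this position, with a number at least 1.50 log units higher from compound 3 to compound 4 (beyond the scatter), so the gain is not tied to a single fluorine placement. Where the fluorine sits still counts, with a number 0.50 log units lower from compound 2 to compound 4 (beyond the scatter), and on the same phenyl ring the choice of substituent matters, with a number at least 1.60 log units higher from compound 1 to compound 4 (beyond the scatter). The two large steps each start from a limit of the assay, so they give only a minimum size.

Going by these compounds, whether a methoxy group, an amine or a carboxylic acid on that ring would keep the activity stays open. These numbers also give no reason for the gap between fluoro and cyano.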